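The source may hold more compounds than are shown below. What is called first, only, known or untested is meant among the compounds shown, and "the series" means these compounds.

Three compounds have been tested in an assay on MCF7 cells for inhibition of Monocarboxylate transporter 1 (Homo sapiens), read by scintillation counting, with a stated time of 10 min; on this read-out lower numbers stand for stronger inhibition and higher numbers for weaker inhibition:

Compound 1 `CC(C)Cn1c(=O)n(C)c(=O)c2[nH]c(=O)c(Cc3cccc4ccccc34)nc21`: "not determined" (no result reported)
Compound 2 `CC(C)Cn1c(=O)n(C)c(=O)c2c1nc(Cc1cccc3ccccc13)c(=O)n2CCCCO`: 548 nM
Compound 3 `CC(C)Cn1c(=O)n(C)c(=O)c2nc(SCCCCO)c(Cc3cccc4ccccc34)nc21`: 669 nM

Compound 3 gives the higher of the two numbers on record, but its gap to compound 2 lies within the usual scatter, so the two cannot be told apart; compound 1 carries no number.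

Compound 4 `CC(C)Cn1c(=O)n(C)c(=O)c2nc(CCCCO)c(Cc3cccc4ccccc34)nc21` differs from compound 3 in a single place: 4-hydroxybutyl in place of (4-hydroxybutyl)sulfanyl on an aromatic carbon. Within the data shown here, no pair of measured compounds differing in one place exists here, so no step size can be read from the data. The step from compound 3 to compound 4 is expected to be a 1.0-fold higher number from compound 3 to compound 4 (0.02 log units; within the scatter), nothing beyond the scatter. Compound 4 is therefore estimated at 700 nM, with a range from 300 nM to 1600 nM.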

Compound 4, half-maximal inhibitory concentration: > 2000 nM
Compound 4 gave a limit, no number (the forecaster's own chance of this, stated with the estimate: 5%); middle value at least 2.8-fold (0.45 log units) from the limit.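

In this assay, compound 4 gives > 2000 nM, which is a limit of the assay and not a number. Putting 4-hydroxybutyl in place of (4-hydroxybutyl)sulfanyl on this aromatic carbon gives an at least 2.9-fold higher number from compound 3 to compound 4 (0.47 log units; beyond the scatter), so the sulfur atom joining the chain to the ring matters here, even though the hydroxybutyl chain itself remains. The full size of this step stays unknown: the limit of > 2000 nM in this assay, at which 1 of the 4 values shown sits.

Still open, from the compounds shown here alone, is whether an oxygen or an amine nitrogen joining the chain to the ring would serve as well as sulfur. A longer chain on the sulfur is also untested among the compounds shown, and nothing here tells why the sulfur link counts.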